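A few compounds are considered here, and "the series" means these few. Any claim that something is new, unique, unknown or untested is made for them only; others in the source may bear on it.

Measured in an assay for inhibition of Thromboxane-A synthase (Homo sapiens), using microsomes; a lower number here means a stronger inhibitor, a higher number a weaker inhibitor:
- compound 1, `CC(C)(Oc1ccccc1)C1OCC(C/C=C\CCC(=O)O)C(c2cccnc2)O1`: 52 nM
- compound 2, `COc1ccc(OC(C)(C)C2OCC(C/C=C\CCC(=O)O)C(c3cccnc3)O2)cc1`: 41 nM

For the measured compounds named here, compound 2 has the lower of the two numbers, but its only neighbour is compound 1, and the step of a 1.3-fold lower number from compound 1 to compound 2 (0.10 log units; within the scatter) lies within the scatter, so on these numbers the two compounds cannot be told apart. Compound 3, `CC(C)(Oc1ccccc1F)C1OCC(C/C=C\CCC(=O)O)C(c2cccnc2)O1`, has not yet been measured. Relative to compound 2 it carries 2-fluorophenyl in place of 4-methoxyphenyl on an oxygen on a saturated carbon. Going by the values given here, only one measured step bears on this change: a 1.3-fold lower number from compound 1 to compound 2 (0.10 log units; within the scatter) shows that putting a methoxy in place of hydrogen on an aromatic carbon made no difference beyond the scatter, so removing that methoxy again should not move the number either. Among the compounds with values here, the fluorine on the ring has no counterpart among the measured compounds, so its effect cannot be read from the data. The expected step is therefore a 1.3-fold higher number from compound 2 to compound 3 (0.13 log units; within the scatter), nothing beyond the scatter, with a wide range to allow for the untested fluorine. Compound 3 is estimated at 55 nM, between 20 nM and 160 nM.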

Compound 3, half-maximal inhibitory concentration: 45 nM
Estimate against measurement, compound 3: 1.2-fold (0.09 log units) above; measured number inside the range.
By their numbers in this assay, from the lowest: compounds 2, 3 and 1 (each within the scatter of the next).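

In this assay, for the compounds shown here, fluoro in place of hydrogen on an aromatic carbon gives a 1.2-fold lower number from compound 1 to compound 3 (0.06 log units; within the scatter) and so does not separate the two compounds, which is the first reading for a halogen on this ring. The larger exchange of 2-fluorophenyl in place of 4-methoxyphenyl on an oxygen on a saturated carbon gives a 1.1-fold higher number from compound 2 to compound 3 (0.04 log units; within the scatter) and also stays within the scatter, so compounds 1, 2 and 3, carrying hydrogen, methoxy or fluoro on this ring, cannot be told apart by their numbers. No measurement shown here offers a reason for this sameness.

The three compounds cover only small groups on this ring, so a trifluoromethyl, an amine or a second phenyl ring could still shift the number beyond the scatter, and nothing shows how a compound with more than one group on the ring would read. Each group has also been seen in a single ring position, leaving open whether a fluoro as in 4-fluorophenyl or a methoxy as in 2-methoxyphenyl would read the same.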